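Working notes: cytotoxicity before the next amide variation

This account rests on a few compounds, and the source may have more. Where it says the series, first, only, none or still open, it means among the compounds named here.

Measured so far:
compound 1 `Cn1c(-c2cccc(C#N)c2)cnc1NC(=O)c1ncc[nH]1`: > 50000 nM
compound 2 `COc1ccc(-c2cnc(NC(=O)C3CCCC3)n2C)cc1`: > 100000 nM
compound 3 `O=C(Nc1ncc(-c2ccccc2)o1)c1ccc(F)cc1`: 17000 nM

In a toxicity assay on THP-1 cells (Homo sapiens) for inhibition (on this read-out higher numbers stand for lower toxicity in this test and lower numbers for higher toxicity in this test), compound 2 gives only a limit, > 100000 nM, which is the limit of > 100000 nM in this assay, at which 1 of the 3 values shown sits. Compound 1 also sits at a limit, > 50000 nM, which is the limit of > 50000 nM in this assay, at which 1 of the 3 values shown sits. For the measured compounds named here, compound 3 is the one compound with a number, 17000 nM. Compound 2 therefore stands at the least toxic end of what has been shown, but without a number attached to it.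

Compound 4 `COc1ccc(-c2cnc(NC(=O)c3ccc(C)cc3)n2C)cc1` is the next compound. It differs from compound 2 by 4-methylphenyl in place of cyclopentyl on a carbonyl carbon. Going by the values given here, no step between measured compounds covers this change, and compound 3 has a different core, so it gives no direct guide.

Compound 4 is expected to land at 50000 nM, with a range from 15000 nM to 150000 nM. The expected step of an at least 2.0-fold lower number from compound 2 to compound 4 (0.30 log units; that floor lies within the scatter) is thus toward higher toxicity, of a size near the edge of the scatter, and a limit rather than a number remains a fair possibility.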

Compound 4, half-maximal cytotoxic concentration: > 100000 nM
Compound 4: no number, only a limit (the forecaster's own chance of this, stated with the estimate: 45%); middle value at least 2.0-fold (0.30 log units) away from the limit.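

Compound 4 also gives only a limit, > 100000 nM, as compound 2 does, so no step can be read between compound 2 and compound 4. The compounds shown leave open whether 4-methylphenyl in place of cyclopentyl on a carbonyl carbon changes the half-maximal cytotoxic concentration at all.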